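Taking one propyl off compound 2

A few compounds are considered here, and "the series" means these few. Any claim that something is new, unique, unknown or untested is made for them only; others in the source may bear on it.

In a functional assay on K562 cells (Homo sapiens) for cytotoxicity, read by MTT assay, with a stated time of 72 h (a lower number here means a stronger inhibitor, a higher number a weaker inhibitor), compound 1 `CC(C)NC(=S)N/N=C1\CC(c2ccc(O)cc2)Oc2cc(O)ccc21` gives 21300 nM and compound 2 `CCCN(CCC)C(=S)N/N=C1\CC(c2ccc(O)cc2)Oc2cc(O)ccc21` gives 12400 nM. These two values lie within the usual scatter of each other, so neither compound can be ranked above the other. The next compound is compound 3 `CCCNC(=S)N/N=C1\CC(c2ccc(O)cc2)Oc2cc(O)ccc21`, which has hydrogen in place of propyl on an amide-type nitrogen. Among the measured compounds shown here, only one measured step bears on this change: a 1.7-fold lower number from compound 1 to compound 2 (0.23 log units; within the scatter), which put dipropylamino in place of isopropylamino and stayed within the scatter. Like compound 3, compound 1 keeps a hydrogen on that nitrogen, and compound 1 gives 21300 nM. A small drift toward a higher number is therefore expected, but nothing beyond the scatter. The expected change is a 1.5-fold higher number from compound 2 to compound 3 (0.16 log units; within the scatter). In this assay, the estimate for compound 3 is 18000 nM, with an expected range from 8000 nM to 35000 nM.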

Compound 3, half-maximal inhibitory concentration: 31000 nM
Beside the measured number, compound 3's estimate is 1.7-fold (0.24 log units) below it, and the stated range covers the measured number.
By their numbers in this assay, from the lowest: compounds 2, 1 and 3 (each within the scatter of the next, the first and the last beyond it).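

Taking one propyl off the dipropylamino group gives the first step in this set that clears the scatter: in this assay the change is a 2.5-fold higher number from compound 2 to compound 3 (0.40 log units; beyond the scatter) and so a second propyl on this amide-type nitrogen can matter. The picture is not simple, since compound 1 also keeps a hydrogen there yet stays within the scatter of compound 2, and a 1.5-fold higher number from compound 1 to compound 3 (0.16 log units; within the scatter) does not separate propyl from isopropyl on this nitrogen. Nothing available here explains the difference between compound 2 and compound 3.

Still open, going by these compounds, is how a shorter group such as methyl or a longer chain such as butyl would read at this nitrogen. Also open, on these data alone, is whether a ring amine such as piperidine, in place of dipropylamino, would behave like compound 2.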